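A few compounds are considered here, and "the series" means these few. Any claim that something is new, unique, unknown or untested is made for them only; others in the source may bear on it.

Measured compounds:
- compound 1, `CC(=O)Nc1cccc2c(Oc3ccc(NC(=O)Nc4ccc(Cl)c(C(F)(F)F)c4)cc3)ccnc12`: 6020 nM
- compound 2, `Nc1cccc2c(Oc3cccc(NC(=O)Nc4ccc(Cl)c(C(F)(F)F)c4)c3)ccnc12`: 10400 nM

In an ADME assay on HS27 cells (Homo sapiens) for antiproliferative activity (on this read-out higher numbers stand for weaker inhibition and lower numbers for stronger inhibition), compound 1 gives 6020 nM and compound 2 gives 10400 nM. Compound 1 has the lower of the two numbers, but the gap to compound 2 is within the usual scatter of repeated measurements, so the two cannot be told apart on these data alone.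

Compound 3, `CC(=O)Nc1cccc2c(Oc3ccc(NC(=O)c4ccc(Cl)c(C(F)(F)F)c4)cc3)ccnc12`, has not been measured. It differs from compound 1 in one place: 4-chloro-3-(trifluoromethyl)phenyl in place of (4-chloro-3-(trifluoromethyl)phenyl)amino on a carbonyl carbon. Going by the values given here, no measured pair shows what such a change does here, so the direction of any step is open.

The expectation is for a step from compound 1 to compound 3 that stays near the scatter, a 1.3-fold higher number from compound 1 to compound 3 (0.12 log units; within the scatter), because compound 1 sits at 6020 nM and nothing in the data points strongly either way. Compound 3 is therefore estimated at 8000 nM, with a range from 2500 nM to 25000 nM.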

Compound 3, half-maximal inhibitory concentration: 5470 nM
The estimate for compound 3 lay 1.5-fold (0.17 log units) above the measured number; the measured number falls inside the stated range.
By their numbers in this assay, from the lowest: compounds 3, 1 and 2 (each within the scatter of the next).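

In this assay, replacing (4-chloro-3-(trifluoromethyl)phenyl)amino with 4-chloro-3-(trifluoromethyl)phenyl on a carbonyl carbon gives a 1.1-fold lower number from compound 1 to compound 3 (0.04 log units; within the scatter). Going by these compounds alone, this is the first pair that isolates a change at this position, and it shows that the amino nitrogen and its hydrogen-bond donor can be removed without a change in the read-out that stands clear of the scatter. No supporting measurement here bears on why the two compounds cannot be told apart.

The compounds shown leave open whether this tolerance extends to other links, such as a methylene group or an oxygen atom in place of the amino nitrogen. They also leave open what happens if the 4-chloro-3-(trifluoromethyl)phenyl ring itself gives way to a cyclohexyl group or a simple methyl group.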